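A Second Fluoro on Compound 3

The compounds below may be only part of what the source reports. "The series", "measured", "known", "first", "only" and "open" are said of these compounds alone.

Of the compounds shown here, three built on a shared core have been measured so far. In a functional assay on MCF7 cells (Homo sapiens) for inhibition, read by resazurin assay, with a stated time of 24 h (on this read-out lower numbers stand for stronger inhibition and higher numbers for weaker inhibition), compound 1 (`O=C1Nc2c(C(F)(F)F)cccc2C1(c1ccc(O)cc1)c1ccc(OC(F)(F)F)cc1`) gives 20 nM as its half-maximal inhibitory concentration. Compound 2 (`O=C1Nc2c(C(F)(F)F)cccc2C1(c1ccc(O)cc1)N1CCC(F)(F)CC1`) gives 35 nM on the same read-out. Compound 3 (`O=C1Nc2c(C(F)(F)F)cccc2C1(c1ccc(OC(F)(F)F)cc1)c1ccc(O)c(F)c1`) gives 33 nM and so lies within the scatter of both other compounds.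

Compound 4 (`O=C1Nc2c(C(F)(F)F)cccc2C1(c1ccc(OC(F)(F)F)cc1)c1cc(F)c(O)c(F)c1`) has not yet been measured. Its difference from compound 3 is fluoro in place of hydrogen on an aromatic carbon and, cut one bond further out, it reads 3-fluoro-4-hydroxyphenyl to 3,5-difluoro-4-hydroxyphenyl. The new fluoro stands ortho to the hydroxy group.

Among the compounds with values here, only one measured step is of the same kind, fluoro in place of hydrogen on an aromatic carbon. That step is a 1.7-fold higher number from compound 1 to compound 3 (0.22 log units; within the scatter) and it stays within the scatter. A single step of this size offers no ground for expecting a clear shift, though it leans slightly towards a higher number. The expected result in this assay is a 1.2-fold higher number from compound 3 to compound 4 (0.08 log units; within the scatter) and this would be no change beyond the scatter. For compound 4 the estimated value is 40 nM with 16 nM to 100 nM as the expected range.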

Compound 4, half-maximal inhibitory concentration: > 1000 nM
Compound 4: only a limit was reported; the forecaster's own chance of this, stated with the estimate: 2%; middle value at least 25-fold (1.39 log units) from the limit.
By their numbers in this assay, from the lowest: compounds 1, 3 and 2 (each within the scatter of the next). At a limit, above all of these: compound 4.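

In this assay compound 4 is recorded only as a limit of the assay, not as a number: the limit of > 1000 nM in this assay, at which 1 of the 4 values shown sits.

Within the data shown here, the second fluoro, placed ortho to a hydroxy group and meta to the first fluoro, gives an at least 30-fold higher number from compound 3 to compound 4 (1.48 log units; beyond the scatter), whereas the only earlier change of this kind gave a 1.7-fold higher number from compound 1 to compound 3 (0.22 log units; within the scatter), so the same replacement on the same ring can be nearly silent once and decisive the next time. Set against the plain 4-hydroxyphenyl group, the 3,5-difluoro-4-hydroxyphenyl group gives an at least 50-fold higher number from compound 1 to compound 4 (1.69 log units; beyond the scatter), which shows that among these compounds this ring carries one fluoro with no change beyond the scatter but does not carry two without a large loss of inhibition.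

The compounds shown leave open whether a chloro or a methyl group at this place would act as the second fluoro does, or whether the loss belongs to fluoro alone. They also leave open whether a methoxy group or an amine in place of the hydroxy group on the 3,5-difluoro ring would give a similar result.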